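Branching a Side Chain Across Two Related Cores

The source may report more compounds than this note shows. Statements on the series, on what has been measured and on what is new or still open speak of the compounds shown alone.

Compound 1 `CCCOC(=O)C1=C(C)NC(=S)NC1c1ccco1` and compound 2 `CC1=C(C(=O)OCC(C)C)C(c2ccco2)NC(=S)N1` share one core, while compound 3 `CCCC(=O)C1=C(C)NC(=O)NC1c1ccsc1` and compound 4 `CC1=C(C(=O)CC(C)C)C(c2ccsc2)NC(=O)N1` share another. In an assay on membranes from CHO cells for displacement of a labelled ligand from adenosine receptor A1 (Homo sapiens), read by scintillation counting, with a stated time of 60 min, tested at 1 uM (a lower number here means less inhibition, a higher number more inhibition at the concentration tested (going by the name of the read-out)), compound 1 gives 1%, and compound 2 gives 7%. The change between them, (methyl in place of hydrogen on a saturated chain carbon bound to two saturated chain carbons), made a step of a number 6 percentage points higher from compound 1 to compound 2 (within the scatter). In this assay compound 3 gives 6%. The difference between the core of compound 1 and the core of compound 3 is not broken down here. Compound 4 carries the same change relative to compound 3, (methyl in place of hydrogen on a saturated chain carbon bound to two saturated chain carbons), and the place of the change reads the same word for word in both pairs. The earlier step of a number 6 percentage points higher from compound 1 to compound 2 (within the scatter) stayed within the scatter. On that basis a step of a number 3 percentage points higher from compound 3 to compound 4 (within the scatter) is expected. Compound 4 is estimated to give about 9% in this assay, most likely between -4% and 22%.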

Compound 4, a percentage reported as inhibition, at one concentration (the size of the read-out at that concentration, not a potency): 37%
For compound 4 the middle estimate is 28 percentage points below the measured one, and the stated range ends below it.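

In this assay, the change did not carry over at one size from the core of compound 1 to the core of compound 3, and the new step is a number 31 percentage points higher from compound 3 to compound 4 (beyond the scatter). Set beside the earlier step, the two differ: the same change on two cores in this assay, a number 6 percentage points higher (within the scatter) from compound 1 to compound 2 and a number 31 percentage points higher (beyond the scatter) from compound 3 to compound 4, 25 percentage points apart, beyond the scatter of two such steps. This shows that a step seen on one core was a poor guide to the same step on the other, but with a single pair on each core it does not show which part of the cores matters, or how the change would behave on a third core.

The compounds shown leave open how a longer chain, such as pentyl, would read on the core of compound 3. They also leave open whether a chain ending in an amine would keep the higher number of compound 4.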